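This account rests on a few compounds, and the source may have more. Where it says the series, first, only, none or still open, it means among the compounds named here.

Measured so far in an assay on LtK cells with ATP-sensitive inward rectifier potassium channel 11 (Homo sapiens) as the target; on this read-out higher numbers stand for an effect only at larger amounts of compound and lower numbers for an effect already at smaller amounts:
compound 1 `O=C(Nc1c(C(O)(C(F)(F)F)C(F)(F)F)ccc2ccccc12)c1cccc(C(F)(F)F)c1` – 84 nM
compound 2 `O=C(Nc1c(C(O)(C(F)(F)F)C(F)(F)F)ccc2ccccc12)c1ccc(C(F)(F)F)cc1` – 160 nM

Within the data shown here, compound 2 has the highest of the two numbers, but its only neighbour, compound 1, lies within the scatter of it: a 1.9-fold higher number from compound 1 to compound 2 (0.28 log units; within the scatter). Among the measured compounds shown here, on the numbers so far, compound 2 and compound 1 cannot be told apart.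

Compound 3 `O=C(Nc1c(C(O)(C(F)(F)F)C(F)(F)F)ccc2ccccc12)c1ccco1` is the next one to be measured. It differs from compound 2 by furan-2-yl in place of 4-(trifluoromethyl)phenyl on a carbonyl carbon. For the measured compounds named here, the single measured step concerns only a move of the trifluoromethyl group within a six-membered ring and did not reach beyond the scatter; no measured step replaces a six-membered ring by a five-membered one or removes the trifluoromethyl group. The expectation for compound 3 therefore rests on the change alone and carries a wide range. Compound 3 is expected at 600 nM, in the range 150 nM to 3000 nM. The step from compound 2 that this estimate means is expected to be a 3.8-fold higher number from compound 2 to compound 3 (0.57 log units; beyond the scatter), an upward move beyond the scatter.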

Compound 3, half-maximal effective concentration: 9 nM
Beside the measured number, compound 3's estimate is 67-fold (1.82 log units) above it, and the stated range ends above it.
By their numbers in this assay, from the lowest: compound 3; then compounds 1 and 2 (each within the scatter of the next).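

In this assay, the group on a carbonyl carbon whose other neighbour is the amide-type nitrogen proves able to shift the number well beyond the scatter: furan-2-yl in place of 4-(trifluoromethyl)phenyl gives an 18-fold lower number from compound 2 to compound 3 (1.25 log units; beyond the scatter) and furan-2-yl in place of 3-(trifluoromethyl)phenyl gives a 9.3-fold lower number from compound 1 to compound 3 (0.97 log units; beyond the scatter). At this place, neither a six-membered aromatic ring nor a trifluoromethyl group is needed for an effect at small amounts of compound. No supporting data bear on what underlies this shift.

The change alters ring size, introduces a ring oxygen and removes the trifluoromethyl group in one step, so the compounds shown do not separate these features. Open, from the compounds shown here alone, is where an unsubstituted phenyl, a thiophen-2-yl or a furan-3-yl would fall relative to furan-2-yl.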